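The source may report more compounds than this note shows. Statements on the series, on what has been measured and on what is new or still open speak of the compounds shown alone.

Measured compounds:
- compound 1, `NC(=O)c1c(NC(=O)c2ccccc2Cl)sc2c1CCN(C(=S)Nc1ccccc1Br)C2`: 10800 nM
- compound 2, `NC(=O)c1c(NC(=O)c2ccccc2Br)sc2c1CCN(C(=S)Nc1ccccc1Cl)C2`: 12900 nM

In a functional assay on MKN-74 cells (Homo sapiens) for antiproliferative activity, with a stated time of 24 h (on this read-out lower numbers stand for stronger inhibition and higher numbers for weaker inhibition), compound 1 gives 10800 nM and compound 2 gives 12900 nM. For the measured compounds named here, the two numbers lie within the scatter of each other, so compound 2 cannot be told apart from compound 1 on this assay; both sit in the same weak region, and no step between measured compounds is available.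

Compound 3, `NC(=O)c1c(NC(=O)c2cccc([N+](=O)[O-])c2)sc2c1CCN(C(=S)Nc1ccccc1Cl)C2`, is not yet measured. It differs from compound 2 in one place: 3-nitrophenyl in place of 2-bromophenyl on a carbonyl carbon. Going by the values given here, with no measured step to rest on, the only ground is the closeness of compound 1 and compound 2, and the change is confined to the ring on the carbonyl carbon. The expected step from compound 2 to compound 3 is therefore a 1.0-fold higher number from compound 2 to compound 3 (0.00 log units; within the scatter), that is, none beyond the scatter in either direction. Compound 3 is estimated at 13000 nM, with a range from 5000 nM to 35000 nM.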

Compound 3, half-maximal inhibitory concentration: 8850 nM
Compound 3: the middle estimate sits 1.5-fold (0.17 log units) above what was measured; the measured number falls inside the stated range.
By their numbers in this assay, from the lowest: compounds 3, 1 and 2 (each within the scatter of the next).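

In this assay, 3-nitrophenyl in place of 2-bromophenyl on the carbonyl carbon gives a 1.5-fold lower number from compound 2 to compound 3 (0.16 log units; within the scatter) and leaves the series in the same weak region. For the compounds shown here, this position therefore accepts a larger ring substituent carrying hydrogen-bond acceptors without a change that can be told from the scatter, although the single step alters both the substituent and its place on the ring and cannot separate the two. No measurement on hand bears on why the read-out stays there.

Still open, as far as these compounds go, is whether an aminophenyl or a carboxyphenyl ring, or a saturated ring such as cyclohexyl, on this carbonyl carbon would move the number beyond the scatter. Equally open, from the compounds shown here alone, is whether any change at this position would matter with a group other than 2-chlorophenyl on the thiourea nitrogen.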